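Compound 2 to compound 4: removing the methyl

The source may report more compounds than this note shows. Statements on the series, on what has been measured and on what is new or still open speak of the compounds shown alone.

In a functional assay on PC-3 cells (Homo sapiens) for inhibition, read by sulforhodamine B assay (on this read-out higher numbers stand for weaker inhibition of growth and lower numbers for stronger inhibition of growth), the measured compounds give these values:
- compound 1 `COc1ccc(-c2ccc(-c3ccc(-c4nc5cc(C)ccc5[nH]4)cc3)cc2)cc1OC` gives 2560 nM
- compound 2 `COc1cc(-c2ccc(-c3ccc(-c4nc5cc(C)ccc5[nH]4)cc3)cc2)cc(OC)c1OC` gives 180 nM
- compound 3 `COc1ccc(-c2ccc(-c3ccc(-c4nc5ccccc5[nH]4)cc3)cc2)cc1` gives 100000 nM

Compound 2 has the lowest number of the three, and its gaps to compound 1 and compound 3 lie beyond the scatter. Compound 4 `COc1cc(-c2ccc(-c3ccc(-c4nc5ccccc5[nH]4)cc3)cc2)cc(OC)c1OC` is still unmeasured. Its difference from compound 2 is hydrogen in place of methyl on an aromatic carbon and reads as 5-methyl-1H-benzimidazol-2-yl to 1H-benzimidazol-2-yl, hydrogen in place of methyl on an aromatic carbon.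

Among the compounds with values here, no measured step isolates this change. Within the data shown here, the only step, a 14-fold lower number from compound 1 to compound 2 (1.15 log units; beyond the scatter) and large, is methoxy in place of hydrogen on an aromatic carbon, so it bears only indirectly. It shows that one replacement can move the number a long way here. Compound 3 also lacks the methyl, but it differs from compound 2 in its methoxy groups too, so compound 3 at 100000 nM cannot separate the two changes. A moderate move towards a higher number is therefore expected, stated as a 3.1-fold higher number from compound 2 to compound 4 (0.49 log units; beyond the scatter) in the estimate. Compound 4 is estimated at 550 nM with 150 nM to 4000 nM as the expected range.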

Compound 4, concentration for 50% growth inhibition: 9720 nM
Compound 4: middle estimate off by 18-fold (1.25 log units), on the low side; the whole stated range lies below it.
By their numbers in this assay, from the lowest: compound 2; then compound 1; then compound 4; then compound 3.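

In this assay, the change from 5-methyl-1H-benzimidazol-2-yl to 1H-benzimidazol-2-yl now has a direct reading, with a 54-fold higher number from compound 2 to compound 4 (1.73 log units; beyond the scatter) as a large step. All the methoxy groups of compound 2 remain in compound 4, so this step belongs to the methyl alone, and this aromatic carbon is a sensitive position even though only one heavy atom leaves. The compounds shown offer no measurement that accounts for the size of this step.

On these data alone, whether an ethyl group or a chlorine atom on this carbon would hold or lower the number remains open. Also open, as far as these compounds go, is whether the methyl counts for as much with the methoxy patterns of compound 1 and compound 3, since neither has a partner differing only at this carbon.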